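The source may hold more compounds than are shown below. What is called first, only, known or untested is meant among the compounds shown, and "the series" means these compounds.

Measured so far in an in vitro ADME assay on microsomes from liver (Homo sapiens) for metabolic stability; a lower number here means slower removal, a higher number faster removal of the compound 
- compound 1 `O=C(COCc1ccccc1)N1CCN(c2ccc(Cl)cc2)CC1` gives 290 mL.min-1.g-1 
- compound 2 `O=C(COCc1ccccn1)N1CCN(c2ccc(Cl)cc2Cl)CC1` gives 94 mL.min-1.g-1 

Compound 2 holds the lower of the two numbers, and the gap to compound 1 lies beyond the scatter. Compound 3 `O=C(COCc1cscn1)N1CCN(c2ccc(Cl)cc2Cl)CC1` carries 1,3-thiazol-4-yl in place of pyridin-2-yl on a saturated chain carbon bound to an oxygen on a saturated carbon. For the measured compounds named here, no measured pair isolates this change, so the estimate stays wide. A step within the scatter is expected in this assay, leaning slightly upward. The expected change is a 1.3-fold higher number from compound 2 to compound 3 (0.11 log units; within the scatter) for now. Compound 3 is estimated at 120 mL.min-1.g-1 with an expected range from 55 mL.min-1.g-1 to 260 mL.min-1.g-1 in this read-out.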

Compound 3, intrinsic clearance in microsomes: 62 mL.min-1.g-1
The estimate for compound 3 lay 1.9-fold (0.29 log units) above the measured number, and the stated range covers the measured number.
By their numbers in this assay, from the lowest: compounds 3 and 2 (each within the scatter of the next); then compound 1.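

For the compounds shown here, this is the first pair that isolates the group on the saturated chain carbon bound to an oxygen on a saturated carbon. In this assay, 1,3-thiazol-4-yl in place of pyridin-2-yl gives a 1.5-fold lower number from compound 2 to compound 3 (0.18 log units; within the scatter), so exchanging the six-membered aromatic ring for this five-membered one leaves the number within the scatter. No available measurement explains this step. Still open, as far as these compounds go, is whether a non-aromatic group at this place, such as an amine or a carboxylic acid, would move the number beyond the scatter.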